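The compounds below may be only part of what the source reports. "The series", "measured", "known", "first", "only" and "open" are said of these compounds alone.

Notes on the series. In an assay on isolated protein for inhibition of N-acylethanolamine-hydrolyzing acid amidase (Homo sapiens), read by fluorescence, with a stated time of 90 min (a higher number here means a weaker inhibitor, a lower number a stronger inhibitor), compound 2 `COc1ccc(-c2ccc(CO[C@H]3C[C@@H](N=C=S)C3)c(F)c2)cc1F` gives 20.6 nM. Among the compounds with values here, on the two numbers so far compound 2 stands highest; its only neighbour is compound 1 `COc1ccc(-c2ccc(C(C)O[C@H]3C[C@@H](N=C=S)C3)c(F)c2)cc1F`, which in this assay gives 14.6 nM, and the step of a 1.4-fold higher number from compound 1 to compound 2 (0.15 log units; within the scatter) stays within the scatter. That single measured step concerns hydrogen in place of methyl on a saturated chain carbon bound to an aromatic carbon and an oxygen on a saturated carbon, a different place from the one now in question.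

Compound 3 `CCOc1ccc(-c2ccc(CO[C@H]3C[C@@H](N=C=S)C3)c(F)c2)cc1F` differs from compound 2 by methyl in place of hydrogen on a saturated chain carbon bound to an oxygen on an aromatic ring, the methoxy read as becoming ethoxy. Within the data shown here, no measured step touches this position, so nothing speaks directly to it. Among the measured compounds shown here, the only available comparison is indirect: the one single-carbon change tried so far, the step of a 1.4-fold higher number from compound 1 to compound 2 (0.15 log units; within the scatter), left the number within the scatter. On that basis the expected step is a 1.2-fold higher number from compound 2 to compound 3 (0.08 log units; within the scatter), nothing beyond the scatter in either direction. Compound 3 is therefore estimated at 25 nM, with a range from 8 nM to 80 nM, pending the measurement.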

Compound 3, half-maximal inhibitory concentration: 69.2 nM
For compound 3 the middle estimate is 2.8-fold (0.44 log units) below the measured one; low and high end bracket the measured number.
By their numbers in this assay, from the lowest: compounds 1 and 2 (each within the scatter of the next); then compound 3.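

In this assay, the change from methoxy to ethoxy gives a 3.4-fold higher number from compound 2 to compound 3 (0.53 log units; beyond the scatter), so a single added methyl on a saturated chain carbon bound to an oxygen on an aromatic ring does weaken inhibition, and this place is not indifferent to the change. The earlier step, a 1.4-fold higher number from compound 1 to compound 2 (0.15 log units; within the scatter), lies at another place, on a saturated chain carbon bound to an aromatic carbon and an oxygen on a saturated carbon, so the series now holds one methyl difference within the scatter and one beyond it, and the result at one place cannot be carried over to the other. Nothing available on these compounds accounts for the step at the methoxy position.

The compounds shown leave open whether a longer chain, such as propoxy, or a branched one, such as isopropoxy, would move the number further in the same direction, and whether a hydroxyl in place of methoxy would reverse it. Also open, as far as these compounds go, is whether ethoxy has the same effect when the methyl of compound 1 is present on the other chain carbon.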